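The source may report more compounds than this note shows. Statements on the series, on what has been measured and on what is new or still open speak of the compounds shown alone.

Working notes on the series. Of the compounds shown here, two have numbers so far: compound 1 `O=C(Nc1cccc(-n2cc(-c3ccncc3)c(-c3cc(O)cc(Cl)c3)n2)c1)Nc1ccc(Cl)c(C(F)(F)F)c1` and compound 2 `COc1cc(Cl)cc(-c2nn(-c3cccc(NC(=O)Nc4cc(C(F)(F)F)cc(C(F)(F)F)c4)c3)cc2-c2ccncc2)c1`. In a functional assay on COLO 205 cells (Homo sapiens) for inhibition, read by sulforhodamine B assay, with a stated time of 48 h, tested at 0.1 uM (a higher number here means a weaker effect of the compound at the concentration tested, a lower number a stronger effect), compound 2 gives 98%. In this assay compound 1 gives 95%, a number within the scatter of that of compound 2, so the two show the same picture. Compound 3 `COc1cc(Cl)cc(-c2nn(-c3cccc(NC(=O)Nc4cccc(C(F)(F)F)c4)c3)cc2-c2ccncc2)c1` is not yet measured; it differs from compound 2 by hydrogen in place of trifluoromethyl on an aromatic carbon. Going by the values given here, no step between measured compounds is known. For compound 3 a step of a number 3 percentage points lower from compound 2 to compound 3 (within the scatter) is expected, none beyond the scatter. Compound 3 is estimated at 95%, with a range from 80% to 102%.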

Compound 3, a percentage reported as activity, at one concentration (the size of the read-out at that concentration, not a potency): 101%
Estimate against measurement, compound 3: 6 percentage points below; low and high end bracket the measured number.
By their numbers in this assay, from the lowest: compounds 1, 2 and 3 (each within the scatter of the next).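

In this assay, hydrogen in place of trifluoromethyl on this aromatic carbon gives a number 3 percentage points higher from compound 2 to compound 3 (within the scatter), the first step read at this position. Compound 2 and compound 3 therefore show the same picture, and at this single concentration the trifluoromethyl group that leaves makes no difference beyond the scatter. No available evidence bears on the reason for this result. From the compounds shown here alone, whether an amine or a carboxylic acid on this aromatic carbon would move the read-out remains open. Also open, going by these compounds, is whether compound 2 and compound 3 would separate at a higher concentration.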